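Swapping tert-butyl for cyclohexyl at one aromatic carbon

The source may hold more compounds than are shown below. What is called first, only, known or untested is meant among the compounds shown, and "the series" means these compounds.

Compound 1 `O=C(/C=C/c1ccc([N+](=O)[O-])o1)c1ccc(Br)cc1` gives 2700 nM
Compound 2 `CC(C)(C)c1ccc(C(=O)/C=C/c2ccc([N+](=O)[O-])o2)cc1` gives 28600 nM
Compound 3 `CC(C)(C)c1ccc(C(=O)/C=C/c2ccco2)cc1` gives 18500 nM

In a functional assay on C6 cells (Rattus norvegicus) for inhibition, read by sulforhodamine B assay, with a stated time of 72 h (on this read-out higher numbers stand for an effect only at larger amounts of compound and lower numbers for an effect already at smaller amounts), compound 3 gives 18500 nM, a number within the scatter of compound 2 at 28600 nM, while compound 1 at 2700 nM stands clearly lower, beyond the scatter. The next compound to be measured is compound 4 `O=C(/C=C/c1ccco1)c1ccc(C2CCCCC2)cc1`, which carries cyclohexyl in place of tert-butyl on an aromatic carbon. Among the compounds with values here, two measured steps bear on this change. The step of an 11-fold higher number from compound 1 to compound 2 (1.03 log units; beyond the scatter) came with tert-butyl in place of bromo on an aromatic carbon, and it is large, so a change at this place can move the number. That step, however, replaced bromo, whereas the groups leaving and entering here are both of carbon only. The step of a 1.5-fold lower number from compound 2 to compound 3 (0.19 log units; within the scatter) lies within the scatter and concerns nitro elsewhere, so it bears only indirectly. No step beyond the scatter is therefore expected in this assay, though the large step of an 11-fold higher number from compound 1 to compound 2 (1.03 log units; beyond the scatter) keeps the range wide. The expected outcome is a 1.1-fold lower number from compound 3 to compound 4 (0.04 log units; within the scatter) as the estimated step. For compound 4 the estimated value is 17000 nM with an expected span of 6000 nM to 45000 nM as its range.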

Compound 4, half-maximal effective concentration: > 50000 nM
Compound 4 gave a limit, no number; the forecaster's own chance of this, stated with the estimate: 10%; middle value at least 2.9-fold (0.46 log units) away from the limit.
By their numbers in this assay, from the lowest: compound 1; then compounds 3 and 2 (each within the scatter of the next). At a limit, above all of these: compound 4.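

In this assay compound 4 gives > 50000 nM, which is a limit of the assay and not a number, and it is the only such value among the compounds shown: the limit of > 50000 nM in this assay, at which 1 of the 4 values shown sits. Even so, the change can be read as an at least 2.7-fold higher number from compound 3 to compound 4 (0.43 log units; beyond the scatter), which shows that this position, on an aromatic carbon of a six-membered aromatic ring of carbon only, tells apart two groups made of carbon alone, with no hydrogen-bond donors or acceptors and no net charge. Within the data shown here, the only earlier step beyond the scatter at this position, an 11-fold higher number from compound 1 to compound 2 (1.03 log units; beyond the scatter), replaced bromo and so could not show this, while the new step moves the number in the same direction on a core that lacks nitro.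

The compounds shown leave open whether cyclohexyl has the same outcome with nitro present, and whether bromo gives a lower number than tert-butyl on the core without nitro as it does on the core with it. They also leave open where a smaller carbon group such as methyl, or a group holding other atoms such as an amine or a carboxylic acid, would fall at this position.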